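A few compounds are considered here, and "the series" means these few. Any claim that something is new, unique, unknown or untested is made for them only; others in the source may bear on it.

Working notes on the series. The shared core appears in compound 1 `O=C(O)c1cccc(C2=C(c3cc(Br)ccc3OCc3ccc(F)cc3)CCC2)c1` and compound 2 `O=C(O)c1cccc(C2=C(c3cc(Br)ccc3OCc3ccc(Cl)cc3)CCC2)c1`. Among the compounds with values here, in an in vivo ADME assay on the whole organism (blood) for pharmacokinetics, with Rattus norvegicus as the target, at a dose of 1 mg/kg by the intravenous route (a lower number here means slower removal, a higher number faster removal of the compound), compound 1 gives 46 mL/min/kg; in this assay compound 2 gives 33 mL/min/kg, the lowest of the two numbers so far, although the step of a 1.4-fold lower number from compound 1 to compound 2 (0.14 log units; within the scatter) lies within the scatter, so the two compounds stand level rather than apart. Compound 3 `O=C(O)c1cccc(C2=C(c3cc(Br)ccc3OCc3ccc(F)cc3F)CCC2)c1` is not yet measured; it differs from compound 2 by 2,4-difluorophenyl in place of 4-chlorophenyl on a saturated chain carbon bound to an oxygen on an aromatic ring. Within the data shown here, the only measured step that bears on this change is the halogen exchange a 1.4-fold lower number from compound 1 to compound 2 (0.14 log units; within the scatter), which stayed within the scatter. Nothing measured covers the addition of a second fluorine. The expectation for compound 3 in this assay is therefore no step beyond the scatter, a 1.2-fold higher number from compound 2 to compound 3 (0.06 log units; within the scatter), a clearance close to the two measured values. Compound 3 is estimated at 38 mL/min/kg, with a range from 22 mL/min/kg to 65 mL/min/kg.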

Compound 3, clearance: 35 mL/min/kg
Compound 3: middle estimate off by 1.1-fold (0.04 log units), on the high side; the measured number falls inside the stated range.
By their numbers in this assay, from the lowest: compounds 2, 3 and 1 (each within the scatter of the next).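

In this assay the second fluorine now has a measured step: fluoro in place of hydrogen on an aromatic carbon gives a 1.3-fold lower number from compound 1 to compound 3 (0.12 log units; within the scatter) and leaves compound 3 level with compound 1. The exchange of 4-chlorophenyl for 2,4-difluorophenyl on a saturated chain carbon bound to an oxygen on an aromatic ring gives a 1.1-fold higher number from compound 2 to compound 3 (0.03 log units; within the scatter), so compound 1, compound 2 and compound 3 show no step beyond the scatter across these halogen patterns. No available evidence accounts for this flat clearance.

From the compounds shown here alone, all three compounds carry only halogen on this phenyl ring, so the effect on clearance of a methoxy group, a nitrile or an amine there remains open. Also open, going by these compounds, is whether a longer chain in place of the benzyl carbon would give a step beyond the scatter.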